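This account rests on a few compounds, and the source may have more. Where it says the series, first, only, none or still open, it means among the compounds named here.

Measured compounds:
compound 1 `CC1=CC[C@@H]([C@@](C)(O)CCCC(C)(C)NC(=S)N/N=C\c2ccc(C)cc2)CC1`
compound 2 `CC1=CC[C@@H]([C@@](C)(O)CCCC(C)(C)NC(=S)N/N=C\c2ccc(N(C)C)cc2)CC1`
To be measured: compound 3 `CC1=CC[C@@H]([C@@](C)(O)CCCC(C)(C)NC(=S)N/N=C(/C)c2ccccc2)CC1`

In a functional assay on K562 cells (Homo sapiens) for cytotoxicity, read by sulforhodamine B assay (a higher number here means that more compound is tolerated, a lower number that less compound is tolerated), compound 1 gives > 100000 nM, which is a limit of the assay and not a number. In this assay compound 2 likewise gives only a limit, > 100000 nM. Going by the values given here, compound 1 therefore stands only at a limit here, and the one further value shown is a limit as well: the limit of > 100000 nM in this assay, at which 2 of the 2 values shown sit. The step that the two limits leave unreadable from compound 1 to compound 2, dimethylamino in place of methyl on an aromatic carbon, cannot be read because both ends sit at the limit of > 100000 nM in this assay, at which 2 of the 2 values shown sit.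

Compound 3 differs from compound 1 by a group of 9 heavy atoms (8 carbon, 1 nitrogen; one six-membered aromatic ring of carbon only) in place of a group of 9 heavy atoms (8 carbon, 1 nitrogen; one six-membered aromatic ring of carbon only), on an amide-type nitrogen. No measured step touches this change; the single step shown alters a different position and is unreadable in any case. Since both values shown sit at the limit (the limit of > 100000 nM in this assay, at which 2 of the 2 values shown sit), the expectation for compound 3 is that it is tolerated up to the limit too, and the step that the limit leaves unreadable from compound 1 to compound 3 is expected to be no larger than the scatter. Compound 3 is expected at 150000 nM, with a range from 50000 nM to 500000 nM.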

Compound 3, concentration lethal to 50% of the cells: 1540 nM
Compound 3: the middle estimate sits 97-fold (1.99 log units) above what was measured, and the stated range ends above it.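

In this assay, the series shows an at least 64-fold lower number from compound 1 to compound 3 (1.81 log units; beyond the scatter), the first readable step among these compounds. The group on the amide-type nitrogen whose other neighbours are the thiocarbonyl carbon keeps the same atoms, the same six-membered aromatic ring of carbon only and its double bond outside aromatic rings, so a change in how those atoms are joined is enough to produce this step, whereas the earlier step at an aromatic carbon, from compound 1 to compound 2, cannot be read. Compound 3 alone has a value that is a number, and the other two compounds remain at a limit of the assay: the limit of > 100000 nM in this assay, at which 2 of the 3 values shown sit.

Compound 3 differs from compound 1 only in this one group, and the data place the step there. They do not separate the contributions of the different connections within the group. Also open, as far as these compounds go, is whether an ethyl group or a pyridine ring within this group on the amide-type nitrogen would keep the lower number, and whether the result in this assay extends beyond K562 cells.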